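The source may report more compounds than this note shows. Statements on the series, on what has been measured and on what is new or still open speak of the compounds shown alone.

Measured so far:
compound 1 `Fc1cccc(F)c1C#Cc1ccc(-n2cccc2)nc1` — 95.3%
compound 2 `Fc1cccc(F)c1C#Cc1nccc2ccccc12` — 96.7%

In a functional assay on LS174T cells (Homo sapiens) for inhibition, with a stated time of 4 days, tested at 10 uM (on this read-out lower numbers stand for a weaker effect and higher numbers for a stronger effect at the one concentration tested), compound 1 gives 95.3% and compound 2 gives 96.7%. Going by the values given here, compound 2 carries the larger of the two numbers, but its nearest neighbour, compound 1, lies within the scatter, so the two cannot be told apart on this assay; no single-point step between measured compounds is known. Both numbers sit close to the top of the read-out, leaving little room for any change to register upward.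

The next compound, compound 3 `Fc1ccc2ccnc(C#Cc3c(F)cccc3F)c2c1`, differs from compound 2 by fluoro in place of hydrogen on an aromatic carbon.

Among the compounds with values here, with no measured step to lean on, the only basis is the position of compound 2 on this assay at 96.7%. A change confined to one fluorine on the shared core is not expected to move the read-out beyond the scatter in either direction; the step of a number 1.7 percentage points lower from compound 2 to compound 3 (within the scatter) is therefore estimated as flat. For compound 3 the expected value in this assay is 95%, within a range of 87% to 99%.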

Compound 3, a percentage reported as inhibition, at one concentration (the size of the read-out at that concentration, not a potency): 96.2%
The estimate for compound 3 lay 1.2 percentage points below the measured number; measured number inside the range.
By their numbers in this assay, from the lowest: compounds 1, 3 and 2 (each within the scatter of the next).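

In this assay, going by these compounds alone, fluoro in place of hydrogen on an aromatic carbon, meta to a fused ring and para to a fused ring, gives a number 0.5 percentage points lower from compound 2 to compound 3 (within the scatter); this is the first single-place step, and it shows that this position takes a fluoro group with no change that can be read on this assay. The step has limited reach: compound 2 and compound 3 both sit close to the top of the read-out at the one concentration tested, so a flat step here does not establish equal potency. No measured data bearing on this result are available to explain it.

Open, going by these compounds, is whether this position stays as tolerant for groups larger than fluoro or of a different kind, such as methoxy, an amine or a carboxylic acid, any of which would test it more sharply than a single fluorine. Also open, on these data alone, is whether compound 2 and compound 3 would separate at lower concentrations, where a read-out away from the top could show a difference that this single-point measurement cannot.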